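A Second Chloro Group on the Core of Compound 1

The source may report more compounds than this note shows. Statements on the series, on what has been measured and on what is new or still open speak of the compounds shown alone.

compound 1, `CCn1c(=O)cc(Cl)[s+]1[O-]`: > 10000 nM
compound 2, `COC(=O)CCn1c(=O)cc(Cl)[s+]1[O-]`: 5600 nM
compound 3, `COC(=O)CCn1sc(Cl)c(Cl)c1=O`: 2600 nM

Of the compounds shown here, three have been measured in an assay on isolated protein for inhibition of histone acetyltransferase KAT2B (Homo sapiens), read by fluorescence, with a stated time of 15 min; a lower number here means a stronger inhibitor, a higher number a weaker inhibitor. Compound 1 gives > 10000 nM, which is a limit of this assay and not a number; this is the limit of > 10000 nM in this assay, at which 1 of the 3 values shown sits. Compound 2 gives 5600 nM. Compound 3 gives 2600 nM.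

Within the data shown here, only one measured step starts from compound 1: an at least 1.7-fold lower number from compound 1 to compound 2 (0.25 log units; that floor lies within the scatter). Because compound 1 sits at the limit (the limit of > 10000 nM in this assay, at which 1 of the 3 values shown sits), only the floor of that step is known.

Compound 4, `CCn1c(=O)c(Cl)c(Cl)[s+]1[O-]`, has not yet been measured. It differs from compound 1 by chloro in place of hydrogen on an aromatic carbon, in words a chloro in place of hydrogen on an aromatic carbon. Among the measured compounds shown here, no measured step exchanges hydrogen for chloro alone. Compound 3, which carries two chloro groups, gives 2600 nM, and compound 2, with one chloro group, gives 5600 nM, but these two also differ at the ring sulfur, so no single change can be read from their gap.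

Compound 4 is therefore expected at about 8000 nM, within a range from 3000 nM to 30000 nM. That estimate means a step of an at least 1.2-fold lower number from compound 1 to compound 4 (0.09 log units; that floor lies within the scatter), small enough that this assay may again report only a limit.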

Compound 4, half-maximal inhibitory concentration: > 10000 nM
Compound 4 gave a limit, no number; the forecaster's own chance of this, stated with the estimate: 45%; at least 1.2-fold (0.09 log units) between middle value and limit.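

In this assay compound 4 gives > 10000 nM, which is a limit and not a number. Compound 1 also sits at a limit, so no step from compound 1 to compound 4 can be read: the limit of > 10000 nM in this assay, at which 2 of the 4 values shown sit.

The compounds shown leave open whether chloro in place of hydrogen on an aromatic carbon changes the inhibition at all.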